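A few compounds are considered here, and "the series" means these few. Any claim that something is new, unique, unknown or untested is made for them only; others in the source may bear on it.

Working notes on the series. Three compounds have been run in a functional assay on HEK293 cells for agonist activity at nuclear receptor subfamily 1 group D member 1 (Homo sapiens), read by a luciferase reporter, with a stated time of 24 h; a higher number here means that more compound is needed for the effect, a lower number that less compound is needed. Compound 1 `Cc1ccc(S(=O)(=O)N(CC(=O)OC(C)(C)C)Cc2ccc([N+](=O)[O-])s2)cc1` gives 3000 nM. Compound 2 `N#CCN(Cc1ccc(Cl)cc1)Cc1ccc([N+](=O)[O-])s1` gives 2500 nM, the lowest of the three numbers; the value of compound 1 lies within the scatter of it, so no order between compound 1 and compound 2 can be read. Compound 3 `O=[N+]([O-])c1ccc(CN(Cc2ccc(Cl)cc2)CC2COc3ccccc3O2)s1` gives 7800 nM, a higher number that lies beyond the scatter from compound 2. Among the measured compounds shown here, no two measured compounds differ in a single place, so no clean single-point step is on hand.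

Compound 4 `CC(=O)N1CCC(CN(Cc2ccc(Cl)cc2)Cc2ccc([N+](=O)[O-])s2)C1` differs from compound 2 in one respect: 1-acetylpyrrolidin-3-yl in place of cyano on a saturated chain carbon bound to an amine nitrogen. The substituent entering is a ring-bearing group of eight heavy atoms in place of a two-atom nitrile, with the count of acceptors unchanged. For the measured compounds named here, the only guidance is that the larger compound 3 gives a higher number than compound 2; a modest rise is therefore expected, possibly not beyond the scatter. The estimate for the step from compound 2 to compound 4 in this assay is a 1.6-fold higher number from compound 2 to compound 4 (0.20 log units; within the scatter). Compound 4 is expected to give 4000 nM in this assay, in the range 1500 nM to 12000 nM, because compound 3 gives 7800 nM where compound 2 gives 2500 nM.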

Compound 4, half-maximal effective concentration: 1600 nM
Compound 4: the middle estimate sits 2.5-fold (0.40 log units) above what was measured; measured number inside the range.
By their numbers in this assay, from the lowest: compounds 4, 2 and 1 (each within the scatter of the next); then compound 3.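

Among the compounds shown here, the only step between compounds that differ in one place is a 1.6-fold lower number from compound 2 to compound 4 (0.19 log units; within the scatter) in this assay, so no order can be read between the two. For the compounds shown here, at this place, on a saturated chain carbon bound to an amine nitrogen, the cyano is thus not required to keep the number in this range: a 1-acetylpyrrolidin-3-yl, with 8 heavy atoms and a five-membered non-aromatic ring in place of 2 heavy atoms and no ring, leaves the read-out within the scatter, which the earlier compounds, differing in more than one place, could not show. Nothing measured on these compounds speaks to why the read-out holds across this change.

The compounds shown leave open how far this tolerance extends, for instance to a carboxylic acid, a free amine such as pyrrolidin-3-yl without the acetyl, or a longer alkyl chain at the same place. They also leave open whether the acetyl or the ring of the entering group matters to the number, as this single step changes both together with the loss of the nitrile.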